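Shortening the hexyl chain of compound 2 to isopropyl

The compounds below may be only part of what the source reports. "The series", "measured", "known", "first", "only" and "open" are said of these compounds alone.

Compound 1 `CC(C)NCC(=O)NCC(=O)N(C)c1ccc(Cl)cc1C(=O)c1ccccc1Cl`: 13 mg/kg
Compound 2 `CCCCCCC(=O)NCC(=O)N(C)c1ccc(Cl)cc1C(=O)c1ccccc1Cl`: 70 mg/kg

In a functional assay on the whole organism with Mus musculus as the target, in the rotarod test (on this read-out higher numbers stand for an effect only at larger amounts of compound and lower numbers for an effect already at smaller amounts), compound 2 gives 70 mg/kg, the higher of the two numbers, and compound 1 is its nearest neighbour. Compound 3 `CC(C)C(=O)NCC(=O)N(C)c1ccc(Cl)cc1C(=O)c1ccccc1Cl` differs from compound 2 in one place, with isopropyl in place of hexyl on a carbonyl carbon.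

Going by the values given here, only one measured step bears on this change, and only indirectly. It is a 5.4-fold higher number from compound 1 to compound 2 (0.73 log units; beyond the scatter), where pentyl took the place of isopropylamino on a saturated chain carbon bound to a carbonyl carbon. Among the compounds with values here, that step altered the same side chain, but no measured pair isolates the change from hexyl to isopropyl, so its size cannot simply be carried over. A move in this assay toward a lower number is expected, smaller than the measured step, though it might not clear the scatter. The expected step is a 2.3-fold lower number from compound 2 to compound 3 (0.37 log units; beyond the scatter). For compound 3 the estimated value is 30 mg/kg, with an expected range of 11 mg/kg to 85 mg/kg.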

Compound 3, dose for half-maximal effect: > 100 mg/kg
Compound 3 gave a limit, no number; the forecaster's own chance of this, stated with the estimate: 15%; middle value at least 3.3-fold (0.52 log units) away from the limit.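

Compound 3 reads only as a limit in this assay, not as a number: the limit of > 100 mg/kg in this assay, at which 1 of the 3 values shown sits.

At this carbonyl carbon, isopropyl in place of hexyl did not bring the number down as the earlier step had suggested, giving an at least 1.4-fold higher number from compound 2 to compound 3 (0.15 log units; that floor lies within the scatter), so the shorter carbon chain shows no gain over hexyl, and how far the two differ stays unsettled. The comparison with the amine is firmer: isopropyl in place of (isopropylamino)methyl gives an at least 7.6-fold higher number from compound 1 to compound 3 (0.88 log units; beyond the scatter), which leaves compound 1 with the lowest number of the three and shows that, among these compounds, neither carbon chain matches the side chain carrying the isopropylamino group.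

The compounds shown do not say whether the low number of compound 1 rests on the amine nitrogen itself or on the side chain as a whole, nor how a primary amine, a dimethylamino group or a carboxylic acid at the end of that chain would read. They also leave open where a butyl chain on the same carbonyl carbon would fall.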